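A few compounds are considered here, and "the series" means these few. Any claim that something is new, unique, unknown or untested is made for them only; others in the source may bear on it.

Working notes on the series. Compound 1 `CC1(C)CC(NC(=O)Nc2cccc(Cl)c2)c2cc(Br)ccc2O1` in a functional assay on T98G cells (Homo sapiens) for inhibition, read by MTT assay, with a stated time of 72 h (on this read-out lower numbers stand for stronger inhibition and higher numbers for weaker inhibition), gives 67000 nM. Compound 2 `CC1(C)CC(NC(=O)NCc2ccccc2)c2cc(Br)ccc2O1` gives 38000 nM in this assay. Compound 3 `CC1(C)CC(NC(=S)Nc2cccc([N+](=O)[O-])c2)c2cc(Br)ccc2O1` gives 4000 nM in this assay. Compound 2 therefore stands second highest of the three numbers: compound 1 is nearest, within the scatter, and compound 3 is furthest, with a gap beyond the scatter. For the measured compounds named here, the only measured step that changes one place, a 1.8-fold lower number from compound 1 to compound 2 (0.25 log units; within the scatter), lies within the scatter and concerns the group on the amide-type nitrogen.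

Compound 4 `CC1(C)CC(NC(=O)NCc2ccccc2)c2cc(Cl)ccc2O1` differs from compound 2 by chloro in place of bromo on an aromatic carbon. Going by the values given here, no measured step bears on this change. Among the compounds with values here, every measured compound carries bromo at that aromatic carbon, and the single measured step touches a different part of the shared core. With nothing in the data pointing in either direction, no step beyond the scatter is expected in this assay. The estimate for compound 4 is 38000 nM, within a range of 15000 nM to 95000 nM. That estimate corresponds to an expected step of no change at the digits printed from compound 2 to compound 4 (within the scatter).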

Compound 4, half-maximal inhibitory concentration: 15000 nM
Beside the measured number, compound 4's estimate is 2.5-fold (0.40 log units) above it; the measured number falls inside the stated range.
By their numbers in this assay, from the lowest: compound 3; then compound 4; then compounds 2 and 1 (each within the scatter of the next).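

The aromatic carbon that carries bromo in compounds 1, 2 and 3 now has its first reading in this assay: chloro in place of bromo gives a 2.5-fold lower number from compound 2 to compound 4 (0.40 log units; beyond the scatter). For the compounds shown here, this modest step is the first single-place change to lie beyond the scatter, so this position registers a change of one heavy atom, whereas the earlier step on the amide-type nitrogen did not clear the scatter. No measurement shown explains why chloro and bromo differ at this position.

From the compounds shown here alone, the reading rests on a single pair carrying the benzyl group, and whether the same change holds with the 3-chlorophenyl group of compound 1 remains open. Going by these compounds, how fluoro, methoxy or an amine at this aromatic carbon would read also remains open.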